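The source may hold more compounds than are shown below. What is called first, only, known or untested is meant among the compounds shown, and "the series" means these compounds.

Measured so far in an assay on HEK-293T cells for antagonist activity at vitamin D3 receptor (Homo sapiens), read by a luciferase reporter, with a stated time of 24 h; on this read-out lower numbers stand for stronger inhibition and higher numbers for weaker inhibition:

Compound 1, `CCC(CC)n1c(-c2ccc(OCc3c(-c4c(Cl)cccc4Cl)noc3C(C)C)cc2)nc2ccc(C(=O)O)cc21`, gives 5690 nM.
Compound 2, `CC(C)c1onc(-c2c(Cl)cccc2Cl)c1COc1ccc(-c2nc3ccc(C(=O)O)cc3n2CC(C)(C)C)cc1`, gives 861 nM.
Compound 3, `CC(C)c1onc(-c2c(Cl)cccc2Cl)c1COc1ccc(-c2nc3ccc(C(=O)O)cc3n2-c2ccc(F)cc2)cc1`, gives 2410 nM.

Among these three, compound 2 has the lowest number in this assay, so it is the strongest inhibitor of the set. The three compounds share one core and differ only in the group attached to an aromatic nitrogen. Swapping that group changed the numbers clearly: a 6.6-fold lower number from compound 1 to compound 2 (0.82 log units; beyond the scatter), a 2.4-fold lower number from compound 1 to compound 3 (0.37 log units; beyond the scatter), and a 2.8-fold higher number from compound 2 to compound 3 (0.45 log units; beyond the scatter). Each of these steps lies beyond the scatter, so the group on this nitrogen is a place where the read-out is sensitive.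

Compound 4, `CC(C)c1onc(-c2c(Cl)cccc2Cl)c1COc1ccc(-c2nc3ccc(C(=O)O)cc3n2C)cc1`, has not yet been measured in this assay. It differs from compound 2 by hydrogen in place of tert-butyl on a saturated chain carbon bound to an aromatic nitrogen. Going by the values given here, no measured pair removes a group at this place outright; the measured steps only exchange one sizeable group for another. All three measured steps bear on the same position and show that changing what sits there moves the number by a modest amount in either direction, and compound 2 is the best of the three. A shift away from the group in compound 2 is therefore expected to raise the number, and compound 4 is estimated at 3000 nM, within a range from 900 nM to 10000 nM, which means an expected step of a 3.5-fold higher number from compound 2 to compound 4 (0.54 log units; beyond the scatter).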

Compound 4, half-maximal inhibitory concentration: 7150 nM
The estimate for compound 4 lay 2.4-fold (0.38 log units) below the measured number; measured number inside the range.
By their numbers in this assay, from the lowest: compound 2; then compound 3; then compounds 1 and 4 (each within the scatter of the next).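

Going by these compounds alone, this is the first compound in which a group at this place is removed rather than swapped for another sizeable one, and in this assay losing the tert-butyl from the saturated chain carbon bound to the aromatic nitrogen gives an 8.3-fold higher number from compound 2 to compound 4 (0.92 log units; beyond the scatter), so the low number of compound 2 depends on that tert-butyl and is not shared by any group on this nitrogen. Methyl also falls behind 4-fluorophenyl, with a 3.0-fold higher number from compound 3 to compound 4 (0.47 log units; beyond the scatter), while methyl and pentan-3-yl cannot be told apart, with a 1.3-fold higher number from compound 1 to compound 4 (0.10 log units; within the scatter), so the bulkier pentan-3-yl group shows no gain over plain methyl even though neopentyl does. Nothing available explains why these groups rank as they do.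

The compounds shown leave open how much of the tert-butyl is needed, since ethyl, isobutyl or a longer straight chain on the nitrogen would fill the gap between methyl and neopentyl. They also leave open whether a cyclohexylmethyl group, or a chain ending in an amine or a hydroxyl, would give a number closer to that of compound 2.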